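The source may hold more compounds than are shown below. What is called first, only, known or untested is meant among the compounds shown, and "the series" means these compounds.

Working notes on the shared core of compound 3 `COCNc1n[n+]([O-])c2ccccc2[n+]1[O-]`. Among the compounds with values here, in a functional assay on PC-3 cells (Homo sapiens) for cytotoxicity, read by MTT assay, with a stated time of 72 h (on this read-out lower numbers stand for stronger inhibition and higher numbers for weaker inhibition), compound 3 gives 7510 nM, the highest of the three numbers so far, though not separated from every neighbour. Compound 2 `[O-][n+]1nc(NCOC2CCCCC2)[n+]([O-])c2ccccc21` gives 3250 nM in this assay, and compound 1 `COc1ccc2c(c1)[n+]([O-])nc(NCOC(C)c1ccccc1)[n+]2[O-]` gives 4140 nM, a number that sits within the scatter of compound 3. Within the data shown here, the only single-point step among the measured compounds is a 2.3-fold higher number from compound 2 to compound 3 (0.36 log units; beyond the scatter), a modest change carried by the group on the oxygen on a saturated carbon.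

Compound 4 `CCCCCOCNc1n[n+]([O-])c2ccccc2[n+]1[O-]` has not yet been measured. It differs from compound 3 by butyl in place of hydrogen on a saturated chain carbon bound to an oxygen on a saturated carbon. The step from compound 2 to compound 3 bears on it: shrinking the group on that oxygen raised the number, and the present change runs the other way, toward a longer chain. A modest fall in this assay is expected, back toward the region of compound 2, without reaching beyond it. Compound 4 is expected at about 3600 nM, with a range from 1700 nM to 7600 nM. The expected step is a 2.1-fold lower number from compound 3 to compound 4 (0.32 log units; beyond the scatter).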

Compound 4, half-maximal inhibitory concentration: 9200 nM
For compound 4 the middle estimate is 2.6-fold (0.41 log units) below the measured one, and the stated range ends below it.
By their numbers in this assay, from the lowest: compounds 2, 1, 3 and 4 (each within the scatter of the next, the first and the last beyond it).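

In this assay, butyl in place of hydrogen on a saturated chain carbon bound to an oxygen on a saturated carbon gives a 1.2-fold higher number from compound 3 to compound 4 (0.09 log units; within the scatter), so the series does not tell methoxy from pentyloxy at this place. Swapping the cyclohexyl for the pentyl chain gives a 2.8-fold higher number from compound 2 to compound 4 (0.45 log units; beyond the scatter), a modest step that matches the one seen with methyl in place of cyclohexyl. Among these three compounds on the same core, only the cyclohexyl of compound 2 stands apart from the others, and chain length shows no trend between compound 3 and compound 4.

From the compounds shown here alone, whether a longer chain, or an amine or a carboxylic acid at the end of the pentyl chain, would move the number away from compound 3 remains open. The data shown offer no explanation for the missing chain-length effect.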